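Notes on a C-X-C chemokine receptor type 3 antagonist pair

This account rests on a few compounds, and the source may have more. Where it says the series, first, only, none or still open, it means among the compounds named here.

Measured so far:
compound 1, `C[C@H]1CN(c2ncc(C(=O)NCc3ccc(F)c(F)c3)cc2Cl)CCN1C1CCN(Cc2ccc(Cl)cc2)CC1`, 6 nM
compound 2, `C[C@H]1CN(C2CCN(Cc3ccc(Cl)cc3)CC2)CCN1c1ncc(C(=O)NCc2ccc(Cl)c(Cl)c2)cc1Cl`, 39 nM

In a functional assay for antagonist activity at C-X-C chemokine receptor type 3 (Homo sapiens) (on this read-out higher numbers stand for weaker inhibition and lower numbers for stronger inhibition), compound 1 gives 6 nM, the lower of the two numbers recorded. Among the measured compounds shown here, compound 2 gives 39 nM in this assay; the two values differ by more than the usual scatter, and no single-point step connects the two structures, so only the two numbers themselves are noted.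

Compound 3, `C[C@H]1CN(c2ncc(C(=N)N)cc2Cl)CCN1C1CCN(Cc2ccc(Cl)cc2)CC1`, has not been measured. It differs from compound 1 by a group of 3 heavy atoms (1 carbon, 2 nitrogen; no ring) in place of a group of 12 heavy atoms (8 carbon, 1 nitrogen, 1 oxygen, 2 fluorine; one six-membered aromatic ring of carbon only), on an aromatic carbon. For the measured compounds named here, the incoming group is far smaller than the one it replaces, and nothing among the measured compounds shows what such a change does in this assay.

For compound 3 a step of an 83-fold higher number from compound 1 to compound 3 (1.92 log units; beyond the scatter) toward a higher number is expected, with wide uncertainty. Compound 3 is estimated at 500 nM, within a range from 80 nM to 3000 nM.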

Compound 3, half-maximal inhibitory concentration: 80 nM
Beside the measured number, compound 3's estimate is 6.3-fold (0.80 log units) above it; measured number inside the range.
By their numbers in this assay, from the lowest: compound 1; then compound 2; then compound 3.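

In this assay, among the compounds shown here, the change from (3,4-difluorobenzyl)carbamoyl to the group of 3 heavy atoms with no ring, on this aromatic carbon para to a large group, gives a 13-fold higher number from compound 1 to compound 3 (1.12 log units; beyond the scatter) and is the first read on this position. The difluorinated ring and the carbamoyl leave together, so the step marks what the whole group contributes and cannot be divided between those parts, while compound 3 at 80 nM keeps measurable inhibition without that ring. Nothing on hand gives a reason for this step.

On these data alone, whether the loss follows from the missing aromatic ring or from the change at the atoms joined to the core remains open. A primary carboxamide, an aminomethyl group or an unsubstituted benzylcarbamoyl at this place would help separate these, and the compounds shown do not settle it.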